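The source may report more compounds than this note shows. Statements on the series, on what has been measured and on what is new or still open speak of the compounds shown alone.

Compounds measured in an assay on cells for inhibition of Voltage-dependent T-type calcium channel subunit alpha-1H (Homo sapiens), read by FLIPR and calcium flux, with stated times of 600 s and 300 s; a higher number here means a weaker inhibitor, a lower number a stronger inhibitor:
- compound 1 `NCCCOc1ccc(CNc2nc3ccc(Oc4ccc(O)cc4)cc3s2)cc1`: 300000 nM
- compound 2 `CN(Cc1ccc(OCCCN)cc1)c1nc2ccc(Oc3ccc(C(F)(F)F)cc3)cc2s1`: 248000 nM
- compound 3 `CN(Cc1ccc(OCCCNC(=N)N)cc1)c1nc2ccc(Oc3ccc(O)cc3)cc2s1`: 332000 nM

The three numbers in this assay sit within the usual scatter of one another; the value of compound 3 is separated from that of compound 1, and from that of compound 2, by less than the scatter, so no ordering among them can be read.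

Compound 4 `CN(Cc1ccc(OCCCN)cc1)c1nc2ccc(Oc3ccc(O)cc3)cc2s1` differs from compound 3 by a hydrogen atom in place of a group of 3 heavy atoms (1 carbon, 2 nitrogen; no ring), on an amine nitrogen. Within the data shown here, no measured pair shows this step. Given that compound 1, compound 2 and compound 3 all give nearly the same number in this assay despite differing substituents, compound 4 is expected to stay in the same region, with a step from compound 3 to compound 4 of a 1.1-fold lower number from compound 3 to compound 4 (0.04 log units; within the scatter), not beyond the scatter. Compound 4 is estimated at 300000 nM, within 150000 nM to 600000 nM.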

Compound 4, half-maximal inhibitory concentration: 165000 nM
Estimate against measurement, compound 4: 1.8-fold (0.26 log units) above; low and high end bracket the measured number.
By their numbers in this assay, from the lowest: compounds 4, 2, 1 and 3 (each within the scatter of the next).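

In this assay, hydrogen in place of the group of 3 heavy atoms on the amine nitrogen gives a 2.0-fold lower number from compound 3 to compound 4 (0.30 log units; within the scatter), so this step does not separate the two compounds. The other two single changes read the same way: hydroxy in place of trifluoromethyl on an aromatic carbon gives a 1.5-fold lower number from compound 2 to compound 4 (0.18 log units; within the scatter), and methyl in place of hydrogen on a nitrogen on an aromatic ring gives a 1.8-fold lower number from compound 1 to compound 4 (0.26 log units; within the scatter). Nothing available explains these numbers. Going by these compounds, whether an acetyl group on that amine nitrogen, a longer chain, or a carboxylic acid in place of the amine would give a number beyond the scatter stays open.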